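A few compounds are considered here, and "the series" means these few. Any claim that something is new, unique, unknown or untested is made for them only; others in the source may bear on it.

Compound 3 `Cc1ccc(S(=O)(=O)N2CCCC[C@H]2CC(=O)N[C@@H]2CCCc3cc(CNC(C)(C)C)ccc32)cc1Cl` gives 22 nM in a functional assay for inhibition of B1 bradykinin receptor (Homo sapiens), read by calcium flux (on this read-out lower numbers stand for stronger inhibition and higher numbers for weaker inhibition), the lowest number among the three measured compounds. Compound 1 `CC(C)(C)NCc1ccc2c(c1)CCC[C@H]2NC(=O)C[C@@H]1CCCCN1S(=O)(=O)c1ccccc1` gives 2400 nM and compound 2 `COc1ccc(S(=O)(=O)N2CCCC[C@H]2CC(=O)N[C@@H]2CCCc3cc(CNC(C)(C)C)ccc32)cc1` gives 1400 nM. The change a 1.7-fold lower number from compound 1 to compound 2 (0.23 log units; within the scatter) is within the scatter, whereas a 110-fold lower number from compound 1 to compound 3 (2.04 log units; beyond the scatter) and a 64-fold lower number from compound 2 to compound 3 (1.80 log units; beyond the scatter) are both large, so the group on the sulfonyl sulfur accounts for nearly all of the spread seen so far. Compound 4 `CC(C)(C)NCc1ccc2c(c1)CCC[C@H]2NC(=O)C[C@@H]1CCCCN1S(=O)(=O)c1cccc2cnccc12` carries isoquinolin-5-yl in place of 3-chloro-4-methylphenyl on a sulfonyl sulfur. For the measured compounds named here, no measured step covers a change of this kind: all three measured groups at this position are single carbon rings, and none holds a hetero atom, so the two large steps only show that the position is responsive and give no direction for a two-ring group. The expected step is a loss relative to compound 3 of uncertain size, estimated as a 14-fold higher number from compound 3 to compound 4 (1.13 log units; beyond the scatter). For compound 4 the estimate in this assay is 300 nM, with an expected range from 30 nM to 3000 nM.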

Compound 4, half-maximal inhibitory concentration: 4300 nM
Beside the measured number, compound 4's estimate is 14-fold (1.16 log units) below it; measured number outside the range, above it.
By their numbers in this assay, from the lowest: compound 3; then compounds 2, 1 and 4 (each within the scatter of the next, the first and the last beyond it).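

In this assay, for the compounds shown here, the two-ring isoquinolin-5-yl on the sulfonyl sulfur does not keep the activity seen with 3-chloro-4-methylphenyl: the series shows a 200-fold higher number from compound 3 to compound 4 (2.29 log units; beyond the scatter), its largest step so far. Against the simpler groups, the series shows a 1.8-fold higher number from compound 1 to compound 4 (0.25 log units; within the scatter) and a 3.1-fold higher number from compound 2 to compound 4 (0.49 log units; beyond the scatter), so a second ring carrying a hetero atom leaves compound 4 with the weak members of the series, and compound 3 alone stands apart among the four. No measurement shown here accounts for the size of this step.

Open, as far as these compounds go, is whether the chlorine or the methyl of 3-chloro-4-methylphenyl carries the activity, which a phenyl bearing only one of the two would settle. Naphthalen-1-yl on the sulfonyl sulfur would separate the second ring from the ring nitrogen.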